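A new amide group on the shared core

The compounds below may be only part of what the source reports. "The series", "measured", "known", "first", "only" and "open" are said of these compounds alone.

Measured in a physicochemical assay for solubility, using the shake flask method, measured as kinetic solubility, with a stated time of 2 h, at pH 7.4 (on this read-out lower numbers stand for lower solubility and higher numbers for higher solubility), so far
- compound 1 `COc1ccc(NC(=O)c2cc(N(C)Cc3ccc(F)cc3)ncn2)cc1` gives 62000 nM
- compound 2 `CN(Cc1ccc(F)cc1)c1cc(C(=O)Nc2ccn(C)n2)ncn1` gives 90000 nM

In this assay compound 2 at 90000 nM cannot be separated from compound 1 at 62000 nM. The two lie within the scatter of each other. Compound 3 `Cc1csc(NC(=O)c2cc(N(C)Cc3ccc(F)cc3)ncn2)n1` is still unmeasured and departs from compound 2 as follows: 4-methyl-1,3-thiazol-2-yl in place of 1-methyl-1H-pyrazol-3-yl on an amide-type nitrogen in one place. Within the data shown here, the only measured step at that place is a 1.5-fold higher number from compound 1 to compound 2 (0.16 log units; within the scatter) and it involves a different pair of groups, so it is a loose guide. No step beyond the scatter is therefore expected. The estimate amounts to a 1.6-fold lower number from compound 2 to compound 3 (0.21 log units; within the scatter) as the expected step. Compound 3 is expected at 55000 nM with an estimated range from 15000 nM to 110000 nM in this read-out.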

Compound 3, solubility: < 5000 nM
Compound 3 was reported as a limit; the forecaster's own chance of this, stated with the estimate: 10%; middle value at least 11-fold (1.04 log units) from the limit.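

The earlier pair showed no separable change on this amide-type nitrogen, but this position is not indifferent to the group it carries. In this assay, 4-methyl-1,3-thiazol-2-yl gives an at least 18-fold lower number from compound 2 to compound 3 (1.25 log units; beyond the scatter) and an at least 12-fold lower number from compound 1 to compound 3 (1.09 log units; beyond the scatter), so two groups of the same heavy-atom count can differ widely here. The value of compound 3 is a limit of the assay, not a number: the limit of < 5000 nM in this assay, at which 1 of the 3 values shown sits.

From the compounds shown here alone, the actual value of compound 3 stays open. So does whether the methyl or the ring sulfur goes with the drop, which a plain 1,3-thiazol-2-yl or a 1,3-oxazol-2-yl group on the same nitrogen could help separate.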